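Chain Extension of an Acid Side Chain in Spirocyclic Amides

A few compounds are considered here, and "the series" means these few. Any claim that something is new, unique, unknown or untested is made for them only; others in the source may bear on it.

Compound 1, `N=C(N)c1ccc(N2CCC3(CCC(C(=O)NCCC(=O)O)CC3)CC2)cc1`: compound 1 gives 5500 nM in a functional assay with Homo sapiens as the target; on this read-out lower numbers stand for stronger inhibition and higher numbers for weaker inhibition
Compound 2, `N=C(N)c1ccc(N2CCC3(CCC(C(=O)NCCCC(=O)O)CC3)CC2)cc1`: compound 2 gives 37100 nM
Compound 3, `O=C(O)CN1CCC2(CCC(C(=O)N3CCN(c4ccncc4)CC3)CC2)CC1`: compound 3 gives 117 nM

Compound 3 shows the lowest number of the three measured compounds. The difference between the core of compound 1 and the core of compound 3 is not broken down here. Within the first pair, the change carboxymethyl in place of carboxy on a saturated chain carbon, two bonds along the chain from an amide-type nitrogen produced the step of a 6.7-fold higher number from compound 1 to compound 2 (0.83 log units; beyond the scatter).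

Compound 4, `O=C(O)CCN1CCC2(CCC(C(=O)N3CCN(c4ccncc4)CC3)CC2)CC1`, has not yet been measured. It relates to compound 3 by carboxymethyl in place of carboxy on a saturated chain carbon bound to an amine nitrogen in a ring. Among the measured compounds shown here, this is the same kind of change as the one from compound 1 to compound 2, but not the same: in the first pair the carbon sits two bonds along the chain from an amide-type nitrogen, whereas in compound 3 it is bound to an amine nitrogen in a ring. A weakening is expected from compound 3 to compound 4 of about a 3.8-fold higher number from compound 3 to compound 4 (0.59 log units; beyond the scatter) because the earlier step was a 6.7-fold higher number from compound 1 to compound 2 (0.83 log units; beyond the scatter), tempered because the place is not identical. Compound 4 is therefore estimated at 450 nM, between 150 nM and 1500 nM.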

Compound 4, half-maximal inhibitory concentration: 7900 nM
Compound 4: the middle estimate sits 18-fold (1.24 log units) below what was measured; the whole stated range lies below it.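

Carboxymethyl in place of carboxy weakened inhibition on both cores in this assay, with a 68-fold higher number from compound 3 to compound 4 (1.83 log units; beyond the scatter) on the core of compound 3, so the direction of the change carried over from one core to the other. Its size did not carry over, as the two steps differ by more than the scatter of two such steps: the same change on two cores in this assay, a 6.7-fold higher number (0.83 log units; beyond the scatter) from compound 1 to compound 2 and a 68-fold higher number (1.83 log units; beyond the scatter) from compound 3 to compound 4, 10-fold (1.00 log units) apart, beyond the scatter of two such steps The two pairs differ in the core and also in the place of the change, which is two bonds along the chain from an amide-type nitrogen in one and on a saturated chain carbon bound to an amine nitrogen in a ring in the other, so they do not show which of these differences sets the size of the step, and two pairs make no rule for further cores.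

The compounds shown leave open how a longer chain ending in a carboxylic acid would read on the core of compound 3. They also leave open whether an ester in place of the carboxylic acid would keep the low number of compound 3.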